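Formyl for Bromo on a Fused Core

A few compounds are considered here, and "the series" means these few. Any claim that something is new, unique, unknown or untested is made for them only; others in the source may bear on it.

Measured in an ADME assay on CCRF-CEM cells (Homo sapiens) for cytotoxicity, with a stated time of 72 h; on this read-out higher numbers stand for weaker inhibition and lower numbers for stronger inhibition:
compound 1 `COc1ccc(-c2nc3sc(Cc4ccc(Cl)cc4)nn3c2Br)cc1` gives 58000 nM
compound 2 `Clc1ccc(Cc2nn3c(Br)c(-c4ccccc4)nc3s2)cc1` gives > 250000 nM, which is a limit of the assay, not a number

Within the data shown here, compound 1 holds the only number in this assay; the other value shown is a limit. Among the measured compounds shown here, the one measured step, an at least 4.3-fold higher number from compound 1 to compound 2 (0.63 log units; beyond the scatter), concerns the methoxy and is judged against (the limit of > 250000 nM in this assay, at which 1 of the 2 values shown sits). Compound 3 `COc1ccc(-c2nc3sc(Cc4ccc(Cl)cc4)nn3c2C=O)cc1` differs from compound 1 in another place: formyl in place of bromo on an aromatic carbon. For the measured compounds named here, no measured step touches the bromo, so the step from compound 1 to compound 2 does not bear on this change, and there is no basis for expecting a shift beyond the scatter in either direction in this assay. Compound 3 is therefore estimated at 60000 nM, within a range of 20000 nM to 200000 nM. That estimate amounts to an expected step of a 1.0-fold higher number from compound 1 to compound 3 (0.01 log units; within the scatter).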

Compound 3, half-maximal inhibitory concentration: 3800 nM
Estimate against measurement, compound 3: 16-fold (1.20 log units) above, and the stated range ends above it.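

In this assay, putting formyl in place of bromo gives a 15-fold lower number from compound 1 to compound 3 (1.18 log units; beyond the scatter), so this aromatic carbon, next to the ring nitrogen, is a place where the read-out responds strongly to a single exchange. Among these compounds, until now the only measured change lay at the methoxy, and this result adds a second place on the shared core where one exchange moves the number beyond the scatter. Both ends of this step are numbers, so its size can be read in full, unlike the step at the methoxy, which ends at a limit: the limit of > 250000 nM in this assay, at which 1 of the 3 values shown sits.

The compounds shown leave open whether the shift follows from the formyl itself or from the loss of bromo, which hydrogen, hydroxymethyl or a carboxylic acid at this carbon could help separate. They also leave open whether formyl has the same effect when a plain phenyl replaces the 4-methoxyphenyl group.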